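The source may hold more compounds than are shown below. What is called first, only, known or untested is meant among the compounds shown, and "the series" means these compounds.

Of the compounds shown here, two built on a shared core have been tested so far in an ADME assay on L929 cells (Mus musculus) for cytotoxicity, read by resazurin assay, with a stated time of 96 h; on this read-out higher numbers stand for lower toxicity in this test and lower numbers for higher toxicity in this test. In it, compound 1 `CC(C)(C)c1ccc(OC/C(=N\NC(N)=S)c2ccc(Br)cc2)cc1` gives 23800 nM, and compound 2 `NC(=S)N/N=C(\COc1ccccc1Cl)c1ccc(Br)cc1` gives 25100 nM. These numbers lie within the usual scatter of repeated measurements, so compound 2 stands level with compound 1 and the two cannot be ranked.

The next molecule is compound 3 `NC(=S)N/N=C(\COc1ccc(I)cc1)c1ccc(Br)cc1`, which differs from compound 2 in a single group: 4-iodophenyl in place of 2-chlorophenyl on an oxygen on a saturated carbon. Here, 4-iodophenyl sits in place of 2-chlorophenyl on an oxygen on a saturated carbon. Within the data shown here, no measured pair yet shows the effect of a single change on its own, so any forecast is rough. The group in this place already differs between compound 1 at 23800 nM and compound 2 at 25100 nM, and those values remain within the scatter of each other. A large shift therefore seems unlikely. The expected step, a 1.3-fold lower number from compound 2 to compound 3 (0.10 log units; within the scatter), is slight, points toward a lower number and stays within the scatter. For compound 3, the estimated half-maximal cytotoxic concentration is 20000 nM, with an expected range of 9000 nM to 45000 nM.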

Compound 3, half-maximal cytotoxic concentration: < 20400 nM
Compound 3 ended at the assay's limit; the forecaster's own chance of this, stated with the estimate: 10%; the middle value is on the limit's open side.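

In this assay compound 3 gives < 20400 nM, which is a limit of the assay and not a number, so its steps can be read only as floors: the limit of < 20400 nM in this assay, at which 1 of the 3 values shown sits.

Swapping the group on the oxygen gives an at least 1.2-fold lower number from compound 2 to compound 3 (0.09 log units; that floor lies within the scatter), and iodo in place of tert-butyl on an aromatic carbon gives an at least 1.1-fold lower number from compound 1 to compound 3 (0.06 log units; that floor lies within the scatter). From the compounds shown here alone, compounds 1 and 2 could not be ranked, whereas these steps give this place its first single-group change with a readable direction, towards a lower number and so higher toxicity in this test, but with both floors within the scatter, the true size of the shift stays unknown and could be slight or much larger.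

The change from 2-chlorophenyl to 4-iodophenyl alters both the halogen and where it sits on the ring, so a group such as 4-chlorophenyl would be needed to separate those two changes. Going by these compounds, how this test would respond to a phenyl ring carrying an amine or a carboxylic acid, or to a longer chain on the oxygen, remains open.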